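The source may report more compounds than this note shows. Statements on the series, on what has been measured and on what is new or still open speak of the compounds shown alone.

Going by the values given here, in a physicochemical assay for solubility, in phosphate buffer, at pH 7.4 (on this read-out higher numbers stand for higher solubility and lower numbers for lower solubility), compound 1 `OCCC1CCN(c2nccnc2OC2CN(c3ccc4ccccc4n3)C2)CC1` gives 84000 nM and compound 2 `c1ccc2nc(N3CC(Oc4nccnc4-c4cccc5ncccc45)C3)ccc2c1` gives 47000 nM, so compound 2 stands within the scatter of the only other measured compound. Compound 3 `c1ccc2nc(N3CC(Oc4nccnc4-c4ccc5scnc5c4)C3)ccc2c1` changes one group of compound 2, with 1,3-benzothiazol-5-yl in place of quinolin-5-yl on an aromatic carbon. Among the compounds with values here, the one measured step at this place, a 1.8-fold lower number from compound 1 to compound 2 (0.25 log units; within the scatter), stayed within the scatter, although it exchanged quite different groups. No shift beyond the scatter is therefore expected, and the expected step is a 1.3-fold lower number from compound 2 to compound 3 (0.13 log units; within the scatter). Compound 3 is estimated at 35000 nM, with an expected range of 12000 nM to 80000 nM.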

Compound 3, solubility: < 1000 nM
Compound 3 gave a limit, no number; the forecaster's own chance of this, stated with the estimate: 5%; at least 35-fold (1.54 log units) between middle value and limit.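

In this assay compound 3 gives a limit and not a number: the limit of < 1000 nM in this assay, at which 1 of the 3 values shown sits. Exchanging two aromatic groups of nearly equal size at this position still gives an at least 47-fold lower number from compound 2 to compound 3 (1.67 log units; beyond the scatter), so a small change here can move the read-out far beyond the scatter. Against the non-aromatic group of compound 1, the exchange for 1,3-benzothiazol-5-yl gives an at least 84-fold lower number from compound 1 to compound 3 (1.92 log units; beyond the scatter).

Which part of 1,3-benzothiazol-5-yl matters, the sulfur, the five-membered ring or its point of attachment, stays open. So does how a simple amine or a carboxylic acid at this position would read in this assay.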